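This account rests on a few compounds, and the source may have more. Where it says the series, first, only, none or still open, it means among the compounds named here.

In an ADME assay for permeability, using PAMPA, with a stated time of 30 min, at pH 7.4 (on this read-out lower numbers stand for lower permeability and higher numbers for higher permeability), compound 2 `COc1ccc(F)cc1CNCCCNc1ccnc2cc(C3CCCCC3)ccc12` gives 23 10^-6 cm/s, level with compound 1 `COc1cccc(CNCCCNc2ccnc3cc(C4CCCCC4)ccc23)c1O` at 23 10^-6 cm/s; together these two stand as the lowest of the three numbers. Compound 3 `c1ccc(Oc2ccc3c(NCCCNCc4ccco4)ccnc3c2)cc1` gives 317 10^-6 cm/s, the highest of the three. Within the data shown here, the only single-point step measured so far, no change at the digits printed from compound 1 to compound 2 (within the scatter), concerns a change on the saturated chain carbon, not the aromatic position. Compound 4 `COc1ccc(F)cc1CNCCCNc1ccnc2cc(Oc3cccc(N(C)C)c3)ccc12` differs from compound 2 by 3-(dimethylamino)phenoxy in place of cyclohexyl on an aromatic carbon. Among the measured compounds shown here, no measured step touches this aromatic carbon, so there is no direct precedent; compound 3, which differs from compound 2 in several places, shows only that considerably higher numbers occur. Compound 4 is therefore estimated at 50 10^-6 cm/s, range 15 10^-6 cm/s to 200 10^-6 cm/s. The expected step of a 2.2-fold higher number from compound 2 to compound 4 (0.34 log units; beyond the scatter) is modest and uncertain in direction.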

Compound 4, apparent permeability: 317 10^-6 cm/s
The estimate for compound 4 lay 6.3-fold (0.80 log units) below the measured number; the measured number lies above the stated range.
By their numbers in this assay, from the lowest: compounds 1 and 2 (each within the scatter of the next); then compounds 3 and 4 (each within the scatter of the next).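

Among these compounds, putting 3-(dimethylamino)phenoxy in place of cyclohexyl on this aromatic carbon gives a 14-fold higher number from compound 2 to compound 4 (1.14 log units; beyond the scatter) in this assay, the first single change that lies beyond the scatter. The change on the saturated chain carbon, by contrast, gives no change at the digits printed from compound 1 to compound 2 (within the scatter) and so leaves the read-out in place. No available evidence accounts for the size of the step. Going by these compounds, whether the step belongs to the ether oxygen, the aromatic ring or the dimethylamino group stays open. A benzyl or pyrrolidine group on this carbon would be a further single change to compare.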